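From bromo to ethylamino on a shared core

This account rests on a few compounds, and the source may have more. Where it says the series, first, only, none or still open, it means among the compounds named here.

In a functional assay on HeLa cells (Homo sapiens) for antiproliferative activity, read by MTT assay, with a stated time of 48 h (a higher number here means a weaker inhibitor, a lower number a stronger inhibitor), compound 1 `COc1ccc(C(=O)c2ccc(OC)c3c2C=CC(C)(C)O3)c(NC(=O)CBr)c1` gives 3680 nM. Compound 3 `CCNCC(=O)Nc1cc(OC)ccc1C(=O)c1ccc(OC)c2c1OC(C)(C)C=C2` lies within the scatter of that number, at 2690 nM. Compound 2 `CNCC(=O)Nc1cc(OC)ccc1C(=O)c1ccc2c(c1)C=CC(C)(C)O2` gives 970 nM. Within the data shown here, that number is lower than the one of compound 1, and the gap lies beyond the scatter.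

The unmeasured compound 4 `CCNCC(=O)Nc1cc(OC)ccc1C(=O)c1ccc(OC)c2c1C=CC(C)(C)O2` keeps the core of compound 1 and carries one change, (ethylamino in place of bromo on a saturated chain carbon bound to a carbonyl carbon), with ethylamino in place of bromo on a saturated chain carbon bound to a carbonyl carbon. Among the measured compounds shown here, no measured pair isolates this change, so the size of the step is uncertain. The nearest guide is compound 3, which also bears ethylamino and gives 2690 nM. A modest fall in the number in this assay is therefore expected, probably not beyond the scatter. The estimated change is a 1.6-fold lower number from compound 1 to compound 4 (0.20 log units; within the scatter). Compound 4 is expected at 2300 nM, within an estimated range of 800 nM to 6000 nM.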

Compound 4, half-maximal inhibitory concentration: 4270 nM
Estimate against measurement, compound 4: 1.9-fold (0.27 log units) below; the range from low to high includes it.
By their numbers in this assay, from the lowest: compound 2; then compounds 3, 1 and 4 (each within the scatter of the next).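

On a saturated chain carbon bound to a carbonyl carbon, the exchange of bromo for ethylamino can now be read directly on the shared core, and in this assay the step is a 1.2-fold higher number from compound 1 to compound 4 (0.06 log units; within the scatter) and lies within the scatter. At this position, then, bromo, with no hydrogen-bond donor, and ethylamino, with one, give numbers that this assay does not tell apart on this core. Nothing measured here explains this result.

From the compounds shown here alone, whether a dimethylamino group, a morpholine ring or a longer chain at this carbon would give a different number remains open. Compound 2, at 970 nM, differs from compound 4 in more than one place, which leaves open whether its methylamino group or its core goes with that lower number.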